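Replacing Bromine with a Fluorophenyl Ring: Expected Clearance

A few compounds are considered here, and "the series" means these few. Any claim that something is new, unique, unknown or untested is made for them only; others in the source may bear on it.

Compound 1 `Nc1ccc(S(=O)(=O)N2CCN(c3ncc(C(O)(C(F)(F)F)C(F)(F)F)cc3Br)CC2)cn1` is the starting point. In an ADME assay (liver) for metabolic stability, with Liver microsome (Homo sapiens) as the target, using microsomes and NADPH, with a stated time of 30 min, tested at 1 uM (a lower number here means slower removal, a higher number faster removal of the compound), compound 1 gives < 14 mL.min-1.g-1, which is a limit of the assay rather than a number. Two measured compounds differ from compound 1 at the same position: compound 2 `Nc1ccc(S(=O)(=O)N2CCN(c3ncc(C(O)(C(F)(F)F)C(F)(F)F)cc3C3CC3)CC2)cn1` carries a cyclopropyl group there and gives 38 mL.min-1.g-1 in this assay, and compound 3 `CC(C)(C)n1cc(-c2cc(C(O)(C(F)(F)F)C(F)(F)F)cnc2N2CCN(S(=O)(=O)c3ccc(N)nc3)CC2)cn1` carries a 1-(tert-butyl)-1H-pyrazol-4-yl group and gives 86 mL.min-1.g-1. Both changes raise the number: an at least 2.7-fold higher number from compound 1 to compound 2 (0.43 log units; beyond the scatter) and an at least 6.1-fold higher number from compound 1 to compound 3 (0.78 log units; beyond the scatter); the step of a 2.3-fold higher number from compound 2 to compound 3 (0.35 log units; beyond the scatter) separates the two.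

Compound 4 `Nc1ccc(S(=O)(=O)N2CCN(c3ncc(C(O)(C(F)(F)F)C(F)(F)F)cc3-c3cccc(F)c3)CC2)cn1` is the next compound. Relative to compound 1 the change is 3-fluorophenyl in place of bromo on an aromatic carbon. This new group is a ring larger than cyclopropyl but smaller than the substituted pyrazole of compound 3, so, judging from the steps shown, a clearly higher number than the limit of compound 1 is expected, placing compound 4 roughly between compound 2 and compound 3. The estimated value for compound 4 in this assay is 55 mL.min-1.g-1, in the range 25 mL.min-1.g-1 to 120 mL.min-1.g-1, which means an expected step of an at least 3.9-fold higher number from compound 1 to compound 4 (0.59 log units; beyond the scatter).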

Compound 4, intrinsic clearance in microsomes: 25 mL.min-1.g-1
Estimate against measurement, compound 4: 2.2-fold (0.34 log units) above; measured number inside the range.
By their numbers in this assay, from the lowest: compounds 4 and 2 (each within the scatter of the next); then compound 3. At a limit, below all of these: compound 1.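

In this assay, the step from the 1-(tert-butyl)-1H-pyrazol-4-yl group to the 3-fluorophenyl ring gives a 3.4-fold lower number from compound 3 to compound 4 (0.54 log units; beyond the scatter), so an aromatic ring at this position does not by itself bring the number of compound 3, while the step from cyclopropyl gives a 1.5-fold lower number from compound 2 to compound 4 (0.18 log units; within the scatter), which leaves those two groups indistinguishable here. The value of compound 1 is only a limit of the assay: the limit of < 14 mL.min-1.g-1 in this assay, at which 1 of the 4 values shown sits. The step from bromo reads an at least 1.7-fold higher number from compound 1 to compound 4 (0.25 log units; that floor lies within the scatter), so even a true rise over bromo is not established for this ring.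

The compounds shown leave open how a plain phenyl ring, an unsubstituted pyrazole or a small amine at this position would compare. They therefore cannot tell whether the fluorine of compound 4 or the tert-butyl group of compound 3 matters to the number.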